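A few compounds are considered here, and "the series" means these few. Any claim that something is new, unique, unknown or untested is made for them only; others in the source may bear on it.

Three compounds share one core and differ at two aromatic positions. Compound 1 `Cc1nn(C)c(Oc2ccc(F)cc2)c1/C=N\OCc1c(Cl)c(-c2ccc(F)cc2)nn1C` gives 6640 nM in a functional assay on SMMC-7721 cells (Homo sapiens) for antiproliferative activity, read by MTT assay, with a stated time of 72 h; on this read-out higher numbers stand for weaker inhibition and lower numbers for stronger inhibition. Compound 2 `COc1ccc(Oc2c(/C=N\OCc3c(Cl)c(-c4ccc(F)cc4)nn3C)c(C)nn2C)cc1` gives 2050 nM in this assay, and compound 3 `Cc1nn(C)c(Oc2ccc(F)cc2)c1/C=N\OCc1c(Cl)c(-c2ccc(Cl)cc2)nn1C` gives 3230 nM. Among these three numbers compound 3 stands second highest: its gap to compound 2 lies within the scatter, whereas a 2.1-fold lower number from compound 1 to compound 3 (0.31 log units; beyond the scatter) lies beyond it. Compound 4 `COc1ccc(Oc2c(/C=N\OCc3c(Cl)c(-c4ccc(Cl)cc4)nn3C)c(C)nn2C)cc1` is compound 3 with methoxy in place of fluoro on an aromatic carbon. Within the data shown here, one measured step bears directly on this change, the same exchange in compound 1, where a 3.2-fold lower number from compound 1 to compound 2 (0.51 log units; beyond the scatter) reached beyond the scatter. Among the measured compounds shown here, no second example of the exchange exists, so the expectation rests on that single step. Compound 4 is therefore expected to show a modest step toward a lower number, a 2.9-fold lower number from compound 3 to compound 4 (0.47 log units; beyond the scatter), in this assay. The estimated value for compound 4 in this assay is 1100 nM, with a range from 500 nM to 2500 nM.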

Compound 4, half-maximal inhibitory concentration: 760 nM
For compound 4 the middle estimate is 1.4-fold (0.16 log units) above the measured one; measured number inside the range.
By their numbers in this assay, from the lowest: compound 4; then compounds 2 and 3 (each within the scatter of the next); then compound 1.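

With compound 4 the exchange of fluoro for methoxy, which turns 4-fluorophenoxy into 4-methoxyphenoxy, has a second example in this assay, a 4.3-fold lower number from compound 3 to compound 4 (0.63 log units; beyond the scatter), so it no longer rests on one step and it holds with chloro in the other aromatic ring: the same change on two cores in this assay, a 3.2-fold lower number (0.51 log units; beyond the scatter) from compound 1 to compound 2 and a 4.3-fold lower number (0.63 log units; beyond the scatter) from compound 3 to compound 4, 1.3-fold (0.12 log units) apart, within the scatter of two such steps

The exchange of fluoro for chloro on the other aromatic ring also repeats, now with methoxy in place, as a 2.7-fold lower number from compound 2 to compound 4 (0.43 log units; beyond the scatter), and so each change keeps its direction in the presence of the other: the same change on two cores in this assay, a 2.1-fold lower number (0.31 log units; beyond the scatter) from compound 1 to compound 3 and a 2.7-fold lower number (0.43 log units; beyond the scatter) from compound 2 to compound 4, 1.3-fold (0.12 log units) apart, within the scatter of two such steps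

The compounds shown leave open whether a hydroxyl, an amine or a longer chain such as ethoxy at this position would lower the number further or reverse the step. They also give no account of why either exchange lowers the number.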